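Swapping the basic side chain for isopropyl on an acyl-sulfamate

The source may hold more compounds than are shown below. What is called first, only, known or untested is meant among the compounds shown, and "the series" means these compounds.

Measured so far:
compound 1 `N=C(N)NCCC[C@H](N)C(=O)NS(=O)(=O)OC[C@H]1OC[C@@H](n2cnc3c(N)ncnc32)C[C@@H]1O` — 600 nM
compound 2 `CC[C@H](C)[C@H](N)C(=O)NS(=O)(=O)OC[C@H]1O[C@@H](n2cnc3c(N)ncnc32)[C@H](O)[C@@H]1O` — 5600 nM
compound 3 `N=C(N)NCCC[C@H](N)C(=O)NS(=O)(=O)OC[C@H]1OC[C@@H](n2cnc3c(N)ncnc32)[C@H](O)[C@@H]1O` — 600 nM

In a functional assay on PBMC cells (Homo sapiens) for inhibition (on this read-out lower numbers stand for stronger inhibition and higher numbers for weaker inhibition), compound 1 gives 600 nM, level with compound 3 and the lowest of the three numbers; compound 2 sits higher, beyond the scatter. For the measured compounds named here, the only single-point step among the measured compounds, no change at the digits printed from compound 1 to compound 3 (within the scatter), shows that a change on the sugar part leaves the read-out untouched. Compound 4 `CC(C)C[C@H](N)C(=O)NS(=O)(=O)OC[C@H]1OC[C@@H](n2cnc3c(N)ncnc32)C[C@@H]1O` instead alters the amino-acid part: a group of 3 heavy atoms (3 carbon; no ring) in place of a group of 6 heavy atoms (3 carbon, 3 nitrogen; no ring), on a saturated chain carbon, two bonds along the chain from an amine nitrogen and a carbonyl carbon. Going by the values given here, no measured pair isolates this change, since compound 2 differs from compound 1 in the sugar as well as in this group, so its value can only hint that a branched hydrocarbon side chain comes with a higher number. On that hint compound 4 is expected to lose some inhibition, with a step of a 5.0-fold higher number from compound 1 to compound 4 (0.70 log units; beyond the scatter) anticipated in this assay. The estimated value for compound 4 is 3000 nM, most likely between 800 nM and 12000 nM.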

Compound 4, half-maximal inhibitory concentration: 6800 nM
Compound 4: the middle estimate sits 2.3-fold (0.36 log units) below what was measured; low and high end bracket the measured number.
By their numbers in this assay, from the lowest: compounds 1 and 3 (each within the scatter of the next); then compounds 2 and 4 (each within the scatter of the next).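

For the compounds shown here, this is the first pair that isolates the amino-acid part: with the sugar part held fixed, isopropyl in place of the group of 6 heavy atoms gives an 11-fold higher number from compound 1 to compound 4 (1.05 log units; beyond the scatter) in this assay. The read-out therefore depends on what this saturated chain carbon carries, unlike the sugar change, which gave no change at the digits printed from compound 1 to compound 3 (within the scatter). Nothing measured here explains the loss.

From the compounds shown here alone, since the two groups differ in both nitrogen content and heavy-atom count, it remains open whether a longer hydrocarbon chain would behave like isopropyl or a chain ending in a simple amine would behave like the group in compound 1. Going by these compounds, it is also open whether the sugar change would remain without effect with isopropyl in place.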